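A few compounds are considered here, and "the series" means these few. Any claim that something is new, unique, unknown or untested is made for them only; others in the source may bear on it.

Of the compounds shown here, two with a shared core have so far been tested in a functional assay on T47D cells (Homo sapiens) for cytotoxicity, with a stated time of 72 h, tested at 10 ug/mL; on this read-out higher numbers stand for a stronger effect at the one concentration tested and lower numbers for a weaker effect. Compound 1 `O=c1[nH]nc2n(c1=O)CCN2c1ccccc1` gives 0% in this assay . Compound 2 `Cc1cccc(N2CCn3c2n[nH]c(=O)c3=O)c1C` gives 21%, the highest of the two numbers; its nearest neighbour, compound 1, lies lower by a gap beyond the scatter. Compound 3 `Cc1ccccc1N1CCn2c1n[nH]c(=O)c2=O` has not yet been measured. It differs from compound 2 as hydrogen in place of methyl on an aromatic carbon. Going by the values given here, no step between measured compounds of this exact kind is available, so the size of the effect of hydrogen in place of methyl on an aromatic carbon is unknown. Among the compounds with values here, the two measured values show only that compound 2 sits higher than compound 1. The step of a number 9 percentage points lower from compound 2 to compound 3 (within the scatter) is therefore expected to be a modest fall, within or just beyond the scatter. Compound 3 is thus estimated at 12%, with a range from 0% to 28%.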

Compound 3, a percentage reported as inhibition, at one concentration (the size of the read-out at that concentration, not a potency): 0%
Estimate against measurement, compound 3: 12 percentage points above; low and high end bracket the measured number.
By their numbers in this assay, from the lowest: compounds 1 and 3 (each within the scatter of the next); then compound 2.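

Taking away the methyl that sits ortho to a methyl group and meta to a large group gives a number 21 percentage points lower from compound 2 to compound 3 (beyond the scatter) in this assay, so this position matters when the other methyl is present. A single methyl on the ring does not show the same effect: adding it gives no change at the digits printed from compound 1 to compound 3 (within the scatter). Among these three compounds, then, a clear read-out appears only with both methyl groups on the ring, and one methyl alone is not enough.

No measurement shown gives a reason for this difference. From the compounds shown here alone, it also stays open whether an ethyl group, a chlorine atom or a methoxy group at this position would keep, raise or remove the effect seen with methyl.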